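Removing the Amide Hydrogen at the Benzoxazole Core

This account rests on a few compounds, and the source may have more. Where it says the series, first, only, none or still open, it means among the compounds named here.

Of the compounds shown here, three sharing a core have been measured in an assay on HEK293 cells for inhibition of Fatty-acid amide hydrolase 1 (Homo sapiens), read by fluorescence; a lower number here means a stronger inhibitor, a higher number a weaker inhibitor. Compound 1 `NC(=O)c1cccc(-c2ccc3oc(NC4CCCCC4)nc3c2)c1` returns only a limit of the assay, > 1000 nM; this is the situation described in the limit of > 1000 nM in this assay, at which 1 of the 3 values shown sits. Compound 2 `COc1ccc(-c2ccc3oc(NC4CCCCC4)nc3c2)cc1C` gives 228 nM. Compound 3 `Cn1ccc2cc(-c3ccc4oc(Nc5ccccn5)nc4c3)ccc21` gives 186 nM, the lowest of the two numbers shown, though its gap to compound 2 lies within the scatter of this assay, so no order between the two can be claimed.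

Compound 4 `Cn1ccc2cc(-c3ccc4oc(N5CCn6cccc6C5)nc4c3)ccc21` differs from compound 3 in one place: a group of 9 heavy atoms (7 carbon, 2 nitrogen; one five-membered aromatic ring with 1 hetero atom, one six-membered non-aromatic ring with 2 hetero atoms) in place of a group of 7 heavy atoms (5 carbon, 2 nitrogen; one six-membered aromatic ring with 1 hetero atom), on an aromatic carbon. The group that leaves carries the only hydrogen-bond donor of that part of the molecule; the group that enters carries none. Among the compounds with values here, with no measured pair available that isolates such a change, the expected size of the step in this assay is uncertain, but a modest move toward a higher number is anticipated, as a step of a 2.4-fold higher number from compound 3 to compound 4 (0.38 log units; beyond the scatter). Compound 4 is therefore estimated at 450 nM, within a range of 130 nM to 1500 nM.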

Compound 4, half-maximal inhibitory concentration: 42 nM
The estimate for compound 4 lay 11-fold (1.03 log units) above the measured number, and the stated range ends above it.
By their numbers in this assay, from the lowest: compound 4; then compounds 3 and 2 (each within the scatter of the next). At a limit, above all of these: compound 1.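

Within the data shown here, at this position, on an aromatic carbon of the shared core, the replacement of the (pyridin-2-yl)amino group gives the first readable step in this assay: a 4.4-fold lower number from compound 3 to compound 4 (0.65 log units; beyond the scatter). It shows that the hydrogen-bond donor of the leaving group is not needed for a low number here, since the entering group carries none and the fused ring pair it brings is accepted at this position. Nothing measured here gives a cause for this step.

The change removes the donor and replaces the ring in one move, so the compounds shown leave open which of the two carries the step; a methyl on the amino nitrogen of the (pyridin-2-yl)amino group, or a plain piperidine, would separate them. On these data alone, whether the entering group gives a similar step alongside the other aryl groups on the shared core also remains open.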